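Cytotoxicity notes: varying the benzyl aryl group

A few compounds are considered here, and "the series" means these few. Any claim that something is new, unique, unknown or untested is made for them only; others in the source may bear on it.

Measured so far in an ADME assay on A549 cells (Homo sapiens) for cytotoxicity, read by CellTiter-Glo; a higher number here means that more compound is tolerated, a lower number that less compound is tolerated:
- compound 1 `Cc1c(Cc2ccc(C(C)(C)C)cc2)c(=O)oc2cc(OCC(O)CN3CCC(C(N)=O)CC3)ccc12`: 14700 nM
- compound 2 `Cc1c(Cc2ccc(F)cc2F)c(=O)oc2cc(OCC(O)CN3CCC(C(N)=O)CC3)ccc12`: a limit of this assay, > 100000 nM
- compound 3 `COc1ccc(Cc2c(C)c3ccc(OCC(O)CN4CCC(C(N)=O)CC4)cc3oc2=O)c(Br)c1`: 44400 nM

Compound 3 holds the highest of the two numbers given here; its nearest neighbour is compound 1, and the step of a 3.0-fold higher number from compound 1 to compound 3 (0.48 log units; beyond the scatter) lies beyond the scatter. The value of compound 2 is a limit and not a number, (the limit of > 100000 nM in this assay, at which 1 of the 3 values shown sits). Compared with compound 2, the step of an at least 2.2-fold lower number from compound 2 to compound 3 (0.35 log units; beyond the scatter) is also beyond the scatter, and the step of an at least 6.8-fold higher number from compound 1 to compound 2 (0.83 log units; beyond the scatter) carries the whole range.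

The next compound, compound 4 `Cc1c(Cc2ccc(-c3ccccc3)cc2)c(=O)oc2cc(OCC(O)CN3CCC(C(N)=O)CC3)ccc12`, changes the same position once more: 4-phenylphenyl in place of 2-bromo-4-methoxyphenyl on a saturated chain carbon bound to an aromatic carbon. Compound 4 shares with compound 1 a 4-substituted phenyl carrying a bulky carbon-only group, whereas compound 3 carries a halogen and an ether on its ring. Of the measured steps, a 3.0-fold higher number from compound 1 to compound 3 (0.48 log units; beyond the scatter) bears most directly, and reading it backwards suggests that compound 4 should return toward the value of compound 1, so a modest lower number in this assay is expected for compound 4, about a 3.0-fold lower number from compound 3 to compound 4 (0.47 log units; beyond the scatter).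

Compound 4 is therefore estimated at 15000 nM, within a range of 5000 nM to 50000 nM.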

Compound 4, half-maximal cytotoxic concentration: > 100000 nM
Compound 4 was reported as a limit (the forecaster's own chance of this, stated with the estimate: 8%); at least 6.6-fold (0.82 log units) between middle value and limit.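

Phenyl in place of tert-butyl on an aromatic carbon gives an at least 6.8-fold higher number from compound 1 to compound 4 (0.83 log units; beyond the scatter) in this assay, so a carbon-only substituent on the phenyl ring does not by itself go with the lower number, and among the four compounds the low end rests with the tert-butyl of compound 1 alone. The change to 4-phenylphenyl also gives an at least 2.2-fold higher number from compound 3 to compound 4 (0.35 log units; beyond the scatter), which shows that this position can reach the top of the range with a group of carbon only, with no halogen and no hydrogen-bond acceptor, while compound 2 gets there with its two fluorines. Compound 2 and compound 4 both stand as limits and not as numbers, so the step between them cannot be read: the limit of > 100000 nM in this assay, at which 2 of the 4 values shown sit.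

Going by these compounds, what numbers lie behind those two limits stays open, and so does the order of 2,4-difluorophenyl and 4-phenylphenyl. An amine or a carboxylic acid in place of tert-butyl on an aromatic carbon, or a longer alkyl chain there, would show whether the lower number is particular to tert-butyl or extends to other groups.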